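Triazole nitrogen substituent variation in the diol ether series

The source may hold more compounds than are shown below. What is called first, only, known or untested is meant among the compounds shown, and "the series" means these compounds.

Compound 1 `N#Cc1ccc(Cn2cc(C[C@H](O)COCCOC[C@@H](O)Cc3ccc(-c4ccccc4)cc3)nn2)cc1` gives 7700 nM in a functional assay on SGC-7901 cells (Homo sapiens) for inhibition, read by MTT assay, with a stated time of 72 h (on this read-out lower numbers stand for stronger inhibition of growth and higher numbers for weaker inhibition of growth), the highest of the three numbers shown. Compound 2 `O[C@H](COCCOC[C@@H](O)Cc1cn(Cc2ccc(Oc3ccccc3)cc2)nn1)Cc1ccc(-c2ccccc2)cc1` gives 4500 nM; the step of a 1.7-fold lower number from compound 1 to compound 2 (0.23 log units; within the scatter) lies within the scatter. Compound 3 `CC1=C(CCCCCCCCCCn2cc(C[C@H](O)COCCOC[C@@H](O)Cc3ccc(-c4ccccc4)cc3)nn2)C(=O)c2ccccc2C1=O` gives 390 nM, the lowest number of the three and beyond the scatter from compound 1.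

Compound 4 `O[C@H](COCCOC[C@@H](O)Cc1cn(-c2ccc3c(c2)OCCO3)nn1)Cc1ccc(-c2ccccc2)cc1` differs from compound 1 by 2,3-dihydro-1,4-benzodioxin-6-yl in place of 4-cyanobenzyl on an aromatic nitrogen. Among the measured compounds shown here, the only measured step at this aromatic nitrogen substituent, a 1.7-fold lower number from compound 1 to compound 2 (0.23 log units; within the scatter), was within the scatter, and no measured pair exchanges the benzyl for a ring attached directly to the nitrogen. The step of a 1.3-fold lower number from compound 1 to compound 4 (0.11 log units; within the scatter) is therefore expected to stay within the scatter. For compound 4 the estimate in this assay is 6000 nM, with a range of 2000 nM to 18000 nM.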

Compound 4, concentration for 50% growth inhibition: 6400 nM
The estimate for compound 4 lay 1.1-fold (0.03 log units) below the measured number; measured number inside the range.
By their numbers in this assay, from the lowest: compound 3; then compounds 2, 4 and 1 (each within the scatter of the next).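

In this assay, 2,3-dihydro-1,4-benzodioxin-6-yl in place of 4-cyanobenzyl on the aromatic nitrogen gives a 1.2-fold lower number from compound 1 to compound 4 (0.08 log units; within the scatter). At this position, then, the nitrile and the benzyl link can both go, with a ring attached directly to the nitrogen, and the step stays within the scatter. Nothing measured gives a reason for this result.

Going by these compounds, it remains open whether an amine or a carboxylic acid on the ring at this nitrogen would move the number. Also open, on these data alone, is whether a shorter chain carrying the end group of compound 3 would hold its value.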